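Trading One Chloro for Hydrogen on Compound 2

The compounds below may be only part of what the source reports. "The series", "measured", "known", "first", "only" and "open" are said of these compounds alone.

Among the measured compounds shown here, compound 2 `ClCc1ccccc1Cn1cnc2c(Cl)nc(Cl)nc21` stands lowest of the two numbers measured so far in a functional assay on BT-549 cells (Homo sapiens) for cytotoxicity, read by sulforhodamine B assay, with a stated time of 48 h (on this read-out lower numbers stand for higher toxicity in this test and higher numbers for lower toxicity in this test), where compound 2 gives 4160 nM. For the measured compounds named here, its only neighbour, compound 1 `ClCc1ccc(Cn2cnc3c(Cl)ncnc32)cc1`, differs from it in two places and is not a single step; in this assay compound 1 gives 57500 nM, a number beyond the scatter above that of compound 2. Compound 3 `ClCc1ccccc1Cn1cnc2c(Cl)ncnc21` is reached from compound 2 by one change alone: hydrogen in place of chloro on an aromatic carbon, in words hydrogen in place of chloro on an aromatic carbon. Going by the values given here, no measured pair isolates this change, so its size is not known from the data. The account expects a loss beyond the scatter, since compound 1, which also lacks this chloro, gives 57500 nM, though its other difference clouds the comparison. Compound 3 is therefore expected to give 12000 nM, within a range from 4000 nM to 40000 nM. That estimate means an expected step of a 2.9-fold higher number from compound 2 to compound 3 (0.46 log units; beyond the scatter), smaller than the gap between the two measured compounds.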

Compound 3, concentration lethal to 50% of the cells: 20000 nM
For compound 3 the middle estimate is 1.7-fold (0.22 log units) below the measured one, and the stated range covers the measured number.
By their numbers in this assay, from the lowest: compound 2; then compound 3; then compound 1.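

In this assay, among the compounds shown here, hydrogen in place of the chloro between two ring nitrogen atoms brings a 4.8-fold higher number from compound 2 to compound 3 (0.68 log units; beyond the scatter) as the only change, so the size of this step now stands on its own, free of any other difference between the compounds. The chloro on this aromatic carbon thus separates the two compounds by more than the scatter, and compound 2, which carries it, has the lower number and so the higher toxicity in this test. No measurement at hand explains this step.

The compounds shown do not say whether this step is specific to chloro or whether an amine or a methoxy group on the same aromatic carbon would give a similar number. They also leave open whether adding this chloro to compound 1 would bring a step of similar size.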